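Swapping a Long Ether Tail for Fluorine

This account rests on a few compounds, and the source may have more. Where it says the series, first, only, none or still open, it means among the compounds named here.

Measured so far in a functional assay on HepG2 cells (Homo sapiens) for antiproliferative activity, read by MTT assay, with a stated time of 48 h; a lower number here means a stronger inhibitor, a higher number a weaker inhibitor:
compound 1 `CCCCCCCCCCCCOc1ccc(C(=O)/C=C/c2c(/C=C/c3ccc(OC)cc3)cc(OC)cc2OC)cc1` gives 11.6 ug/mL;
compound 2 `COc1ccc(/C=C/c2cc(OC)cc(OC)c2/C=C/C(=O)c2cccc(Br)c2)cc1` gives 13 ug/mL;
compound 3 `CCCCCCOc1ccc(C(=O)/C=C/c2c(/C=C/c3ccc(OC)cc3)cc(OC)cc2OC)cc1` gives 16.2 ug/mL.

All three numbers sit close together. Among the compounds with values here, compound 3 is separated from compound 1 by a 1.4-fold higher number from compound 1 to compound 3 (0.15 log units; within the scatter), and its gap to compound 2 is also within the scatter, so no compound can be singled out.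

Compound 4 `COc1ccc(/C=C/c2cc(OC)cc(OC)c2/C=C/C(=O)c2ccc(F)cc2)cc1` differs from compound 3 by fluoro in place of hexyloxy on an aromatic carbon. Within the data shown here, the only measured step, from dodecyl to hexyl, barely moved this assay, and compound 2, which carries bromo instead of an ether tail, lands in the same range. Among the measured compounds shown here, no measured step directly tests fluoro here, so compound 4 is expected to show a 1.2-fold lower number from compound 3 to compound 4 (0.10 log units; within the scatter), no real change. The estimate for compound 4 is 13 ug/mL, within 6 ug/mL to 28 ug/mL.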

Compound 4, half-maximal inhibitory concentration: 12.2 ug/mL
Estimate against measurement, compound 4: 1.1-fold (0.03 log units) above, and the stated range covers the measured number.
By their numbers in this assay, from the lowest: compounds 1, 4, 2 and 3 (each within the scatter of the next).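

Putting fluoro in place of hexyloxy on this aromatic carbon gives a 1.3-fold lower number from compound 3 to compound 4 (0.12 log units; within the scatter) in this assay and so removes the whole ether tail without a change beyond the scatter. Changing the ring on the carbonyl carbon, with 4-fluorophenyl in place of 3-bromophenyl, gives a 1.1-fold lower number from compound 2 to compound 4 (0.03 log units; within the scatter) and likewise leaves the number within the scatter. No measurement at hand explains why these compounds give such similar numbers.

On these data alone, whether an amine or a carboxylic acid on this aromatic carbon would move the number beyond the scatter remains open.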